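The source may report more compounds than this note shows. Statements on the series, on what has been measured and on what is new or still open speak of the compounds shown alone.

In a functional assay on HL-60 cells (Homo sapiens) for inhibition, read by MTT assay, with a stated time of 72 h (on this read-out lower numbers stand for stronger inhibition and higher numbers for weaker inhibition), compound 2 `CO[C@@H](c1ccccc1)[C@H]1O[C@@H]2CC(=O)O[C@@H]2[C@H]1O` gives 1630 nM. Compound 3 `CO[C@H](c1ccccc1)[C@H]1O[C@@H]2CC(=O)O[C@@H]2[C@H]1O` lies within the scatter of that value at 2960 nM, while compound 1 `CO[C@@H]1[C@H]2OC(=O)C[C@H]2O[C@@H]1[C@@H](O)c1ccccc1` stands clearly higher at 19000 nM. Compound 4 `CO[C@@H]1[C@H]2OC(=O)C[C@H]2O[C@@H]1[C@@H](OC)c1ccccc1` departs from compound 2 by a single change, methyl in place of hydrogen on an oxygen on a saturated carbon, or hydroxy to methoxy when cut one bond further out.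

Only one measured step joins any of these compounds, a 1.8-fold higher number from compound 2 to compound 3 (0.26 log units; within the scatter). That step rests on (the fact that compounds 2 and 3 differ only in the configuration as drawn), so it gives no size for a methyl on this oxygen. The same methoxy on that saturated carbon also occurs in compound 1, but that compound differs from compound 2 elsewhere as well. Compound 1 at 19000 nM is therefore only a loose hint, pointing towards a higher number rather than measuring this change.

In this assay, a modest move to a higher number is thus expected, with the estimated step being a 1.8-fold higher number from compound 2 to compound 4 (0.26 log units; within the scatter), though the evidence for it is thin. Compound 4 is estimated at 3000 nM, with an expected range of 700 nM to 14000 nM.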

Compound 4, half-maximal inhibitory concentration: 4360 nM
Compound 4: the middle estimate sits 1.5-fold (0.16 log units) below what was measured, within the range that was stated.
By their numbers in this assay, from the lowest: compounds 2, 3 and 4 (each within the scatter of the next, the first and the last beyond it); then compound 1.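

In this assay, the methyl on this oxygen now has a measured size: turning hydroxy into methoxy gives a 2.7-fold higher number from compound 2 to compound 4 (0.43 log units; beyond the scatter), a modest change that lies beyond the scatter, so the free hydroxy at this position goes with the lower number. The same kind of change made on the other oxygen, the one that carries the free hydroxy in compound 1, runs the opposite way, with a 4.4-fold lower number from compound 1 to compound 4 (0.64 log units; beyond the scatter). Among these compounds, then, the direction of a methyl in place of hydrogen depends on which oxygen receives it, and nothing shown here accounts for that reversal.

The compounds shown leave open whether a longer chain such as ethyl, or an acetyl group, on either oxygen would follow the direction seen with methyl. They also leave open whether an amine in place of the hydroxy at this position would keep the number of compound 2 or move it, and whether the drawn configuration of the methoxy-bearing carbon matters once both oxygens carry a methyl.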